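Isopropyl for methyl on the sulfonamide aryl ring

The compounds below may be only part of what the source reports. "The series", "measured", "known", "first", "only" and "open" are said of these compounds alone.

Measured compounds:
compound 1 `Cc1ccc(S(=O)(=O)Nc2nc(-c3cccc([N+](=O)[O-])c3)cs2)cc1` gives 48 nM in an assay on isolated protein for inhibition of kynurenine 3-monooxygenase (Rattus norvegicus); a higher number here means a weaker inhibitor, a lower number a stronger inhibitor
compound 2 `Cc1ccc(S(=O)(=O)Nc2nc(-c3ccc(Cl)c(Cl)c3)cs2)cc1` gives 56 nM in this assay
compound 3 `Cc1ccc(S(=O)(=O)Nc2nc(-c3ccc(O)c(C)c3)cs2)cc1` gives 114 nM in this assay

Compound 1 has the lowest of the three numbers in this assay. Its gap to compound 2 lies within the scatter, so the two cannot be ordered; its gap to compound 3 lies beyond it. Within the data shown here, the one measured step, a 2.0-fold higher number from compound 2 to compound 3 (0.31 log units; beyond the scatter), concerns the aryl group on the shared core, not the sulfonamide side.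

Compound 4 `CC(C)c1ccc(S(=O)(=O)Nc2nc(-c3cccc([N+](=O)[O-])c3)cs2)cc1` differs from compound 1 by isopropyl in place of methyl on an aromatic carbon. No measured step touches this part of the structure, so the expectation rests on the change itself rather than on a shown step. Because the only shown step, a 2.0-fold higher number from compound 2 to compound 3 (0.31 log units; beyond the scatter), was modest, the account expects a change of similar or smaller size here, most likely none beyond the scatter. The estimate for compound 4 in this assay is 60 nM, ranging from 25 nM to 150 nM, which means an expected step of a 1.3-fold higher number from compound 1 to compound 4 (0.10 log units; within the scatter).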

Compound 4, half-maximal inhibitory concentration: 990 nM
For compound 4 the middle estimate is 17-fold (1.22 log units) below the measured one, outside the stated range (above it).
By their numbers in this assay, from the lowest: compounds 1 and 2 (each within the scatter of the next); then compound 3; then compound 4.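

Among these compounds, compound 1's sulfonamide side had not been varied among the earlier compounds, and in this assay this position proves highly sensitive to the change from 4-methylphenyl to 4-isopropylphenyl: the result is a 21-fold higher number from compound 1 to compound 4 (1.31 log units; beyond the scatter), a far larger step than the only earlier one, a 2.0-fold higher number from compound 2 to compound 3 (0.31 log units; beyond the scatter), which lay on the other aryl group. Methyl and isopropyl both count no hydrogen-bond donors or acceptors and no net charge, so a step of this size can occur with those counts unchanged. Nothing shown here bears on why the number rises so far.

The compounds shown leave open how the number responds to a hydrogen, an ethyl, a tert-butyl or a methoxy at this carbon. Going by these compounds, it also remains open whether isopropyl has a similar effect alongside the 3,4-dichlorophenyl of compound 2 or the 4-hydroxy-3-methylphenyl of compound 3.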